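The compounds below may be only part of what the source reports. "The series", "measured", "known", "first", "only" and "open" are said of these compounds alone.

The series was examined in an assay on Sf9 cells for inhibition of histone deacetylase 11 (Homo sapiens), read by fluorescence, tested at 0.5 uM; a lower number here means less inhibition, a higher number more inhibition at the concentration tested (going by the name of the read-out). Compound 1 `O=C(/C=C/c1cn([C@@H]2C[C@@H](CO)N(CCCc3ccccc3)C2)nn1)NO` gives 13% in this assay. Compound 2 `O=C(/C=C/c1cn([C@H]2C[C@@H](C(=O)O)N(CCCc3ccccc3)C2)nn1)NO` gives 29% in this assay, which makes it the higher of the two numbers recorded: compound 1 sits a step lower that is beyond the usual scatter of this measurement.

Compound 3 `O=C(/C=C/c1cn([C@@H]2C[C@@H](C(=O)O)N(CCCc3ccccc3)C2)nn1)NO` has not yet been measured in this assay. Compared with compound 2, (the two compounds have the same atoms and bonds and differ only in configuration as drawn: 1 of 3 stereo elements differ; a stereocentre at a saturated ring carbon is drawn S in compound 2 and R in compound 3). The two compounds therefore share every atom and bond and part only in the drawn configuration at one saturated ring carbon.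

Among the compounds with values here, no measured pair in this set differs by such a change alone, so the size of the step is open. A change of configuration at a single ring carbon is expected to move the read-out by a small amount, most likely downward but not clearly beyond the scatter. Compound 3 is thus estimated to give 21% in this assay, within a range from 6% to 38%. The expected step of a number 8 percentage points lower from compound 2 to compound 3 (within the scatter) is a modest decrease.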

Compound 3, a percentage reported as inhibition, at one concentration (the size of the read-out at that concentration, not a potency): < 10%
Compound 3 was reported as a limit; the forecaster's own chance of this, stated with the estimate: 0%; middle value at least 11 percentage points away from the limit.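

In this assay compound 3 gives < 10%, which is a limit of the assay and not a number. The step is a number at least 19 percentage points lower from compound 2 to compound 3 (beyond the scatter), and it can be put down to the configuration at this saturated ring carbon for one reason: the fact that compounds 2 and 3 differ only in the configuration as drawn. With carboxy in place of hydroxymethyl on a saturated ring carbon, the step is a number at least 3 percentage points lower from compound 1 to compound 3 (that floor lies within the scatter), so this exchange is not shown to change the read-out, although the true step may be larger than that floor.

The limit leaves open how much inhibition compound 3 retains, and so the full size of both steps. The compounds shown also leave open how a carboxamide or a methyl ester on this ring carbon would read in either configuration.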